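The source may report more compounds than this note shows. Statements on the series, on what has been measured and on what is new or still open speak of the compounds shown alone.

In an ADME assay on microsomes from liver (Homo sapiens) for metabolic stability, read by LC-MS, using NADPH, with a stated time of 10 min, tested at 10 uM (a lower number here means that the compound disappears faster, a higher number that the compound lasts longer), compound 1 `Nc1ncnc2c1c(Oc1cc(C(F)(F)F)ccn1)nn2C1CCCC1` gives 0.333 h and compound 3 `Nc1ncnc2c1c(Oc1cc(Cl)ccn1)nn2[C@H]1C[C@H](F)C1` gives 0.833 h as measured numbers. Compound 2 `N#Cc1ccnc(Oc2nn([C@H]3C[C@H](O)C3)c3ncnc(N)c23)c1` gives > 2.41 h which is a limit and not a number. Compound 4 `CC(C)(C)n1nc(Oc2cc(C#N)ccn2)c2c(N)ncnc21` differs from compound 2 in one place, with tert-butyl in place of 3-hydroxycyclobutyl on an aromatic nitrogen and the rest of the structure unchanged. For the measured compounds named here, no measured pair shows this change on its own, and compounds 1 and 3 also differ from compound 2 elsewhere. The expectation therefore leans on compound 1 at 0.333 h and compound 3 at 0.833 h as the two compounds that lack the 3-hydroxycyclobutyl group and still return numbers. A shorter half-life is expected, beyond the usual scatter, with an estimated step of an at least 2.4-fold lower number from compound 2 to compound 4 (0.38 log units; beyond the scatter) in this assay as the likely outcome. For compound 4 the estimated half-life is 1 h with an expected range from 0.4 h to 2.4 h at this stage.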

Compound 4, half-life: > 2.41 h
Compound 4 ended at the assay's limit; the forecaster's own chance of this, stated with the estimate: 15%; middle value at least 2.4-fold (0.38 log units) from the limit.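

In this assay, no step can be read from compound 2 to compound 4 because neither gives a number, only a limit: the limit of > 2.41 h in this assay, at which 2 of the 4 values shown sit.

The compounds shown leave open whether tert-butyl in place of 3-hydroxycyclobutyl on an aromatic nitrogen changes the half-life at all.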